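This account rests on a few compounds, and the source may have more. Where it says the series, first, only, none or still open, it means among the compounds named here.

Of the compounds shown here, three sharing one core have been measured in a functional assay on DLD-1 cells (Homo sapiens), read by microscopy and crystal violet staining, with a stated time of 20 h, tested at 10 ug/mL; a higher number here means more inhibition at the concentration tested (going by the name of the read-out), a lower number less inhibition. Compound 1 `O=C1NC(=S)S/C1=C\C=C\c1ccccc1OS(=O)(=O)c1ccccc1` gives 80%. Compound 2 `O=C1NC(=S)S/C1=C\C=C\c1ccccc1OCc1ccccc1` gives 65%. Compound 3 `O=C1NC(=S)S/C1=C\C=C\c1cccnc1` gives 45%. Among these three numbers compound 2 stands second highest: its nearest neighbour is compound 1, whose number lies higher by a margin beyond the scatter, and its furthest is compound 3, whose number lies lower, again beyond the scatter.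

The account now follows the step from compound 2 to compound 4 `COc1ccccc1/C=C/C=C1\SC(=S)NC1=O`, which has not yet been measured in this assay. The change is hydrogen in place of phenyl on a saturated chain carbon bound to an oxygen on an aromatic ring; cut one bond further out, it reads benzyloxy to methoxy. Among the measured compounds shown here, no pair of measured compounds differs in just this way, so the size of the step cannot be read from the numbers at hand. The ranking in this assay runs from compound 1 through compound 2 to compound 3, and compound 4 carries less on the aromatic ring than compound 2 does, so a downward step is expected, probably beyond the scatter. The step from compound 2 to compound 4 is estimated at a number 15 percentage points lower from compound 2 to compound 4 (beyond the scatter). Compound 4 is therefore expected to give about 50%, within a range from 30% to 68%.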

Compound 4, a percentage reported as inhibition, at one concentration (the size of the read-out at that concentration, not a potency): 69%
Beside the measured number, compound 4's estimate is 19 percentage points below it, outside the stated range (above it).
By their numbers in this assay, from the lowest: compound 3; then compounds 2 and 4 (each within the scatter of the next); then compound 1.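

In this assay, among the compounds shown here, hydrogen in place of phenyl on a saturated chain carbon bound to an oxygen on an aromatic ring comes to a number 4 percentage points higher from compound 2 to compound 4 (within the scatter) and so gives the first direct reading of a change at this place. Cutting benzyloxy back to methoxy removes six carbon atoms and a whole aromatic ring, yet for this pair the inhibition at the one concentration tested stays within the scatter, so the phenyl is not required to retain it. Nothing available explains why so large a removal leaves the number unchanged.

The compounds shown leave open whether the number stays level with other groups on the aromatic ring, such as a longer chain like butoxy, an amine or a carboxylic acid, or with a bare hydrogen in place of methoxy. Since the read-out gives the size of the inhibition at one concentration and not a potency, they also leave open whether compound 2 and compound 4 would still match across a range of concentrations.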